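Benzoate esters of a cadinene-type scaffold: antiproliferative read-out

The source may report more compounds than this note shows. Statements on the series, on what has been measured and on what is new or still open speak of the compounds shown alone.

Measured so far:
- compound 1 `Cc1cc2c(C(C)C)ccc(C)c2cc1OC(=O)c1cccc(C(F)(F)F)c1`: 26.7%
- compound 2 `CC1=CC[C@H](C(C)C)c2cc(C)c(OC(=O)c3cccc(C(F)(F)F)c3)cc21`: 25.4%
- compound 3 `Cc1cc2c(C(C)C)ccc(C)c2cc1OC(=O)c1ccc([N+](=O)[O-])cc1`: 100%

In a functional assay on PC-3 cells (Homo sapiens) for antiproliferative activity, read by sulforhodamine B assay, with a stated time of 48 h, tested at 50 uM (on this read-out lower numbers stand for less inhibition and higher numbers for more inhibition at the one concentration tested (going by the name of the read-out)), compound 2 gives 25.4%. Compound 1 gives 26.7% in this assay, a number within the scatter of that of compound 2, so no order between the two can be claimed. Carrying a nitro group in place of the trifluoromethyl and the aromatic core of compound 1, compound 3 gives 100%, far beyond the scatter from both. Among the measured compounds shown here, no single-point step between measured compounds is available, so the effect of the trifluoromethyl itself is not isolated.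

Compound 4 `CC1=CC[C@H](C(C)C)c2cc(C)c(OC(=O)c3ccccc3)cc21` differs from compound 2 only in one place: hydrogen in place of trifluoromethyl on an aromatic carbon. For the measured compounds named here, nothing among the measured compounds shows what removing this group does on its own; the one large difference seen, that of compound 3, rests on a different group and a different core. For compound 4 the expectation is a step from compound 2 of a number 3.4 percentage points lower from compound 2 to compound 4 (within the scatter), within or near the scatter, with no change beyond it being the likeliest outcome. Compound 4 is estimated at 22%, in the range 8% to 40%.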

Compound 4, a percentage reported as inhibition, at one concentration (the size of the read-out at that concentration, not a potency): 22.5%
Beside the measured number, compound 4's estimate is 0.5 percentage points below it; measured number inside the range.
By their numbers in this assay, from the lowest: compounds 4, 2 and 1 (each within the scatter of the next); then compound 3.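

In this assay, among the compounds shown here, hydrogen in place of trifluoromethyl on an aromatic carbon gives a number 2.9 percentage points lower from compound 2 to compound 4 (within the scatter), the first reading of a single change. On the core shared by these two compounds, the trifluoromethyl can therefore be removed from this position without a change beyond the scatter, so this read-out does not depend measurably on that group here. No evidence on hand bears on why this step is so small.

On these data alone, it remains open whether the nitro group or the core of compound 1 accounts for compound 3 at 100%, since no single-change step connects compound 3 to the others. Also open, as far as these compounds go, is how an amine or a carboxylic acid on this same aromatic carbon would read on the shared core of compound 2 and compound 4.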